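Clearance after a change at one carbonyl carbon

The compounds below may be only part of what the source reports. "The series", "measured", "known", "first", "only" and "open" are said of these compounds alone.

Measured in an ADME assay on microsomes from liver (Mus musculus) for metabolic stability; on this read-out lower numbers stand for slow clearance and higher numbers for fast clearance:
Compound 1 `COc1ccc(S(=O)(=O)Nc2ccc(CN3CCN(C(=O)C4CCCN(C)C4)CC3)cc2)cc1`: 1.5 mL.min-1.g-1
Compound 2 `COc1ccc(S(=O)(=O)Nc2ccc(OC3CCN(C(=O)c4cccc(Cl)c4)CC3)cc2)cc1`: 37 mL.min-1.g-1

Compound 1 holds the lower of the two numbers, and compound 2 lies higher by a gap well beyond the scatter. Compound 3 `COc1ccc(S(=O)(=O)Nc2ccc(CN3CCN(C(=O)Cn4cccnc4=O)CC3)cc2)cc1` has not yet been measured. It keeps the core of compound 1 and differs in one place: a group of 8 heavy atoms (5 carbon, 2 nitrogen, 1 oxygen; one six-membered aromatic ring with 2 hetero atoms) in place of a group of 7 heavy atoms (6 carbon, 1 nitrogen; one six-membered non-aromatic ring with 1 hetero atom), on a carbonyl carbon. The 1-methylpiperidin-3-yl leaves, and a group with a six-membered aromatic ring with 2 hetero atoms enters. Going by the values given here, no measured pair shows this change on its own, so the data offer no direct guide to its size. The expectation therefore starts from compound 1 at 1.5 mL.min-1.g-1. The expected change is a small rise, a 2.3-fold higher number from compound 1 to compound 3 (0.37 log units; beyond the scatter). For compound 3 the estimated value is 3.5 mL.min-1.g-1, with an expected range of 1.2 mL.min-1.g-1 to 11 mL.min-1.g-1.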

Compound 3, intrinsic clearance in microsomes in the Mus musculus assay: < 0.5 mL.min-1.g-1
Compound 3 ended at the assay's limit; the forecaster's own chance of this, stated with the estimate: 10%; middle value at least 7.0-fold (0.84 log units) from the limit.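

On the carbonyl carbon of the core of compound 1, the 1-methylpiperidin-3-yl gives way to a group with a six-membered aromatic ring with 2 hetero atoms, and clearance falls: in the Mus musculus assay the change gives an at least 3.0-fold lower number from compound 1 to compound 3 (0.47 log units; beyond the scatter). In the Mus musculus assay compound 3 gives < 0.5 mL.min-1.g-1, which is a limit of the assay. Compound 3 stands at this limit, so the step has a minimum size and no known full size: the limit of < 0.5 mL.min-1.g-1 in the Mus musculus assay, at which 1 of the 3 values shown sits. In a physicochemical assay for solubility, measured as kinetic solubility (on this read-out higher numbers stand for higher solubility and lower numbers for lower solubility), compound 1 gives >= 526000 nM, which is a limit of the assay. In the physicochemical assay compound 3 gives >= 336000 nM, which is also a limit of the assay. The step between compound 1 and compound 3 in this read-out cannot be read.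

The compounds shown do not separate the loss of the 1-methylpiperidin-3-yl from the entry of the new ring. From the compounds shown here alone, how clearance would read with a morpholine or a carboxylic acid-bearing chain on this carbonyl carbon also stays open.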